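This account rests on a few compounds, and the source may have more. Where it says the series, first, only, none or still open, it means among the compounds named here.

In a functional assay on NB1 cells (Homo sapiens) for cytotoxicity, read by MTT assay, with a stated time of 3 days (a lower number here means a stronger inhibitor, a higher number a weaker inhibitor), compound 1 `N#Cc1c(Cl)nc(SCc2nc3ccccc3[nH]2)nc1-c1ccccc1` gives 2.87 nM and compound 2 `N#Cc1c(NN)nc(SCc2nc3ccccc3[nH]2)nc1-c1ccccc1` gives 5.4 nM. These two numbers lie within the scatter of each other, so compound 2 stands level with compound 1, and the series shows no measured spread so far.

Compound 3 `N#Cc1c(Nc2ccccc2)nc(SCc2nc3ccccc3[nH]2)nc1-c1ccccc1` is the next case. The change is phenyl in place of amino on a nitrogen on an aromatic ring, or aminoamino to anilino when cut one bond further out.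

Among the measured compounds shown here, only one measured step bears on this: a 1.9-fold higher number from compound 1 to compound 2 (0.27 log units; within the scatter). That step exchanged the chloro on an aromatic carbon, and it stayed within the scatter. For the measured compounds named here, neither measured compound carries a phenyl at this place, so the data offer no direct precedent and the range has to stay wide.

No step beyond the scatter is therefore expected in this assay, in either direction. The expected change is a 1.1-fold higher number from compound 2 to compound 3 (0.05 log units; within the scatter). Compound 3 is estimated at 6 nM, with an expected range from 2 nM to 20 nM.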

Compound 3, half-maximal inhibitory concentration: 2.5 nM
Compound 3: the middle estimate sits 2.4-fold (0.38 log units) above what was measured, and the stated range covers the measured number.
By their numbers in this assay, from the lowest: compounds 3, 1 and 2 (each within the scatter of the next, the first and the last beyond it).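

In this assay, among the compounds shown here, the change from aminoamino to anilino, phenyl in place of amino on a nitrogen on an aromatic ring, gives a 2.2-fold lower number from compound 2 to compound 3 (0.33 log units; beyond the scatter), the first step that lies beyond the scatter, although it is only a modest one. Anilino in place of chloro on an aromatic carbon gives a 1.1-fold lower number from compound 1 to compound 3 (0.06 log units; within the scatter), so this place on the shared core holds the one six-membered aromatic ring of anilino with no step beyond the scatter relative to chloro, and compound 3 stands level with compound 1 as well. Nothing available accounts for the modest step between aminoamino and anilino.

From the compounds shown here alone, it remains open whether the step from compound 2 depends on the aromatic ring itself, a question that cyclohexylamino, with its saturated carbon ring, or a simple methylamino group could address at this place. Also open, going by these compounds, is how far the numbers in this assay would move with a methoxy group or a fluorine atom on the phenyl of anilino, or with a morpholine attached directly to the aromatic carbon.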